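The source may report more compounds than this note shows. Statements on the series, on what has been measured and on what is new or still open speak of the compounds shown alone.

Going by the values given here, compound 2 `CC1=CC[C@H](C(C)(C)NC(=S)N/N=C/c2ccccc2O)CC1` is the one compound in this set with a measured number: in a functional assay on OVCAR-3 cells (Homo sapiens) for inhibition, read by sulforhodamine B assay, with a stated time of 48 h (on this read-out higher numbers stand for weaker inhibition of growth and lower numbers for stronger inhibition of growth), compound 2 gives 5500 nM. Its partner compound 1 `CC1=CC[C@H](C(C)(C)NC(=S)N/N=C/c2ccc(O)cc2)CC1` stands at a limit of the assay, > 100000 nM in this assay, so no number is known for it. Among the compounds with values here, the only measured step, an at least 18-fold lower number from compound 1 to compound 2 (1.25 log units; beyond the scatter), therefore rests on a limit of > 100000 nM in this assay, at which 1 of the 2 values shown sits, and can only say that the change was large.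

Compound 3 `CC1=CC[C@H](C(C)(C)NC(=S)N/N=C/c2cccc(Cl)c2)CC1` is the next compound to be measured. It differs from compound 2 in one place: 3-chlorophenyl in place of 2-hydroxyphenyl on a carbon with a double bond to nitrogen. Within the data shown here, the measured step does not bear on this change directly, since it moved a hydroxyl between two positions rather than replacing the hydroxyl with a chlorine, and the only measured number belongs to compound 2. With the hydrogen-bond donor and acceptor of the 2-hydroxyphenyl gone, a weaker inhibition of growth for compound 3 is expected, and the step from compound 2 to compound 3 is estimated as a 3.6-fold higher number from compound 2 to compound 3 (0.56 log units; beyond the scatter). In this assay compound 3 is expected to give about 20000 nM, within a range from 5000 nM to 100000 nM.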

Compound 3, concentration for 50% growth inhibition: 13600 nM
Compound 3: middle estimate off by 1.5-fold (0.17 log units), on the high side; low and high end bracket the measured number.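

Compound 3 shows that a hydroxyl on the phenyl is not needed for a measured number in this assay: the 3-chlorophenyl has 0 hydrogen-bond donors and 0 hydrogen-bond acceptors, yet replacing 2-hydroxyphenyl with it gives only a modest change, a 2.5-fold higher number from compound 2 to compound 3 (0.39 log units; beyond the scatter). Set against the 4-hydroxyphenyl, the same group gives an at least 7.3-fold lower number from compound 1 to compound 3 (0.86 log units; beyond the scatter), so the identity and placement of the substituent on this phenyl both appear to matter, with 2-hydroxyphenyl giving the lowest number of the three compounds and 4-hydroxyphenyl the highest. Compound 1 has a limit and not a number, so the size of that second step is known from one side only: the limit of > 100000 nM in this assay, at which 1 of the 3 values shown sits.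

The change from compound 2 to compound 3 alters both the kind of group and where it sits on the phenyl, so these compounds cannot separate what the swap of hydroxyl for chlorine contributes from what the shift in place contributes. They also leave open how a phenyl carrying a methoxy group or an amine in place of the chlorine would behave in this assay.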